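Removing the carbonyl on the ring nitrogen: compound 4

The compounds below may be only part of what the source reports. "The series", "measured", "known", "first", "only" and "open" are said of these compounds alone.

Measured compounds:
compound 1 `CC1(OC(=O)N2CCC(O[C@H]3CC[C@H](Oc4cnc(S(C)(=O)=O)cn4)CC3)CC2)CC1`: 25.9 nM
compound 2 `CS(=O)(=O)c1cnc(O[C@H]2CC[C@H](OC3CCN(C(=O)Oc4ccccc4)CC3)CC2)cn1`: 9.6 nM
compound 3 `CS(=O)(=O)c1cnc(O[C@H]2CC[C@H](OC3CCN(C(=O)C4(C(F)(F)F)CCCC4)CC3)CC2)cn1`: 38.4 nM

Among the measured compounds shown here, in a functional assay on isolated protein for agonist activity at Glucose-dependent insulinotropic receptor (Homo sapiens), read by HTRF and cAMP accumulation (on this read-out higher numbers stand for an effect only at larger amounts of compound and lower numbers for an effect already at smaller amounts), compound 3 gives the highest number of the three, though it lies within the scatter of compound 1 and only the step of a 4.0-fold higher number from compound 2 to compound 3 (0.60 log units; beyond the scatter) is clear. Compound 4 `CS(=O)(=O)c1cnc(O[C@H]2CC[C@H](OC3CCN(CC4(C(F)(F)F)CCC4)CC3)CC2)cn1` changes compound 3 by a group of 9 heavy atoms (6 carbon, 3 fluorine; one four-membered non-aromatic ring of carbon only) in place of a group of 11 heavy atoms (7 carbon, 1 oxygen, 3 fluorine; one five-membered non-aromatic ring of carbon only), on an amine nitrogen in a ring, so the carbonyl itself disappears. For the measured compounds named here, every compound measured so far keeps that carbonyl; the steps of a 1.5-fold higher number from compound 1 to compound 3 (0.17 log units; within the scatter) and a 4.0-fold higher number from compound 2 to compound 3 (0.60 log units; beyond the scatter) only swap the group on its carbon, and both stay modest. Going by the values given here, no measured step covers loss of the carbonyl, so there is no direct guide. The expectation for compound 4 is therefore a value near that of compound 3, with a wide range, and the expected step of a 1.2-fold higher number from compound 3 to compound 4 (0.07 log units; within the scatter) is estimated as small. Compound 4 is expected to give 45 nM, between 10 nM and 200 nM.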

Compound 4, half-maximal effective concentration: 54.8 nM
Estimate against measurement, compound 4: 1.2-fold (0.09 log units) below; low and high end bracket the measured number.
By their numbers in this assay, from the lowest: compound 2; then compounds 1, 3 and 4 (each within the scatter of the next, the first and the last beyond it).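

In this assay the carbonyl on the ring nitrogen proves dispensable, at least next to compound 3: swapping that acyl group for (1-(trifluoromethyl)cyclobutyl)methyl gives a 1.4-fold higher number from compound 3 to compound 4 (0.15 log units; within the scatter) and so leaves the compound active. The carbamates stay ahead, with a 2.1-fold higher number from compound 1 to compound 4 (0.33 log units; beyond the scatter) and a 5.7-fold higher number from compound 2 to compound 4 (0.76 log units; beyond the scatter) as modest steps beyond the scatter. Nothing available explains these steps. The ring also shrinks from five-membered to four-membered, and that change cannot be told apart from the carbonyl loss. A benzyl group or plain cyclobutylmethyl on this nitrogen remains an open question.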